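Fluoro Aryl Amide Variant of a Flavone Ether Series

This account rests on a few compounds, and the source may have more. Where it says the series, first, only, none or still open, it means among the compounds named here.

Within the data shown here, compound 1 `O=C(COc1c(-c2ccccc2)oc2ccccc2c1=O)Nc1ccc2ccccc2c1` is the one member with a measured number: in a functional assay on NCI-H661 cells (Homo sapiens) for antiproliferative activity, read by MTT assay, with a stated time of 72 h (on this read-out higher numbers stand for weaker inhibition of growth and lower numbers for stronger inhibition of growth), compound 1 gives 6500 nM. Compound 2 `O=C(COc1ccc2c(=O)cc(-c3ccccc3)oc2c1)Nc1ccc2ccccc2c1` reaches only the assay limit, > 10000 nM. Compound 3 `O=C(COc1c(-c2ccccc2)oc2ccccc2c1=O)Nc1ccccc1` likewise gives only a limit, > 10000 nM. Among the measured compounds shown here, the single measured step on the amide nitrogen, an at least 1.5-fold higher number from compound 1 to compound 3 (0.18 log units; that floor lies within the scatter), therefore ends at the floor, where (the limit of > 10000 nM in this assay, at which 2 of the 3 values shown sit). Compound 4 `O=C(COc1c(-c2ccccc2)oc2ccccc2c1=O)Nc1ccc(F)cc1` changes compound 3 by fluoro in place of hydrogen on an aromatic carbon. For the measured compounds named here, no measured step varies a substituent on this phenyl ring, so the expectation rests on compound 3 alone, with the step that the limit leaves unreadable from compound 3 to compound 4 expected to stay within the scatter. Compound 4 is estimated at 12000 nM, ranging from 5000 nM to 30000 nM, most likely again reported as a limit.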

Compound 4, concentration for 50% growth inhibition: > 10000 nM
Compound 4: a limit, no number; the forecaster's own chance of this, stated with the estimate: 65%; the middle value lies beyond the limit too.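

Compound 4 gives only a limit, > 10000 nM, so fluoro on this phenyl ring, para to a large group, yields no number in this assay. Among these compounds, the step between the two limits cannot be read, and the one readable comparison, with the naphthalen-2-yl amide, gives only an at least 1.5-fold higher number from compound 1 to compound 4 (0.18 log units; that floor lies within the scatter). The limit now holds most of the values: the limit of > 10000 nM in this assay, at which 3 of the 4 values shown sit.

As far as these compounds go, it remains open whether compound 3 and compound 4 differ at all past the limit. Also open, from the compounds shown here alone, is whether an amine or a carboxylic acid on this phenyl ring would give a measured number.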